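Chlorine Enters the Four-Membered Ring Series

The compounds below may be only part of what the source reports. "The series", "measured", "known", "first", "only" and "open" are said of these compounds alone.

Within the data shown here, compound 2 `c1ccc2c(c1)CC2CCCN1CCN(c2cccc3c2OCCO3)CC1` gives 646 nM in an assay on isolated protein for binding affinity to 5-hydroxytryptamine receptor 1B (Rattus norvegicus) (a higher number here means a weaker inhibitor, a lower number a stronger inhibitor), the lowest of the two numbers so far; compound 1 `c1ccc2c(c1)CC(CCCN1CCN(c3cccc4c3OCCO4)CC1)C2` gives 1860 nM, and the step of a 2.9-fold lower number from compound 1 to compound 2 (0.46 log units; beyond the scatter) is the only one known. Compound 3 `Clc1cccc2c1CC2CCN1CCN(c2cccc3c2OCCO3)CC1` differs from compound 2 by a group of 9 heavy atoms (8 carbon, 1 chlorine; one four-membered non-aromatic ring of carbon only, one six-membered aromatic ring of carbon only) in place of a group of 9 heavy atoms (9 carbon; one four-membered non-aromatic ring of carbon only, one six-membered aromatic ring of carbon only), on a saturated chain carbon, two bonds along the chain from an amine nitrogen in a ring. Among the measured compounds shown here, the one measured step concerns a different change, the size of the non-aromatic ring, so nothing measured bears directly on compound 3. The change is therefore expected to leave the number roughly where it is, a 1.3-fold lower number from compound 2 to compound 3 (0.11 log units; within the scatter), with wide uncertainty. Compound 3 is estimated at 500 nM, between 150 nM and 2000 nM.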

Compound 3, inhibition constant: 708 nM
Estimate against measurement, compound 3: 1.4-fold (0.15 log units) below; the range from low to high includes it.
By their numbers in this assay, from the lowest: compounds 2 and 3 (each within the scatter of the next); then compound 1.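

In this assay, putting the chlorine-bearing group in place of the all-carbon group of the same heavy-atom count, on a saturated chain carbon, two bonds along the chain from an amine nitrogen in a ring, gives a 1.1-fold higher number from compound 2 to compound 3 (0.04 log units; within the scatter). This exchange therefore produces no step beyond the scatter, unlike the earlier ring-size step, a 2.9-fold lower number from compound 1 to compound 2 (0.46 log units; beyond the scatter). Nothing available explains this result.

Going by these compounds, whether a fluorine or a methoxy group in place of the chlorine would shift the number remains open. So does the effect of a longer chain on the chlorine-bearing group.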